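A few compounds are considered here, and "the series" means these few. Any claim that something is new, unique, unknown or untested is made for them only; others in the source may bear on it.

In an assay on isolated protein for inhibition of lysosomal alpha-glucosidase (Homo sapiens), tested at 1000 uM (on this read-out lower numbers stand for less inhibition and higher numbers for more inhibition at the one concentration tested (going by the name of the read-out)), the three measured compounds stand as follows:

compound 1 `OC[C@]1(c2ccc(F)cc2)NC[C@H](O)[C@H]1O`: 8.3%
compound 2 `COc1cccc([C@@]2(CO)NC[C@H](O)[C@H]2O)c1`: 46%
compound 3 `OC[C@@]1(c2ccccc2)NC[C@@H](O)[C@@H]1O`: 35%

Compound 2 has the highest of the three numbers. Its nearest neighbour is compound 3, whose number lies lower by more than the usual scatter, and the furthest is compound 1, whose number lies lower still, again beyond the scatter. No two of these compounds differ in only one place, so no single step between measured compounds can be isolated.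

Compound 4 `COc1ccc([C@@]2(CO)NC[C@H](O)[C@H]2O)cc1OC` is built from compound 2 by one change: methoxy in place of hydrogen on an aromatic carbon. The new group sits ortho to the methoxy group already present and para to the group of 9 heavy atoms that carries the rest of the molecule.

Among the compounds with values here, nothing among the measured compounds shows what a second methoxy does, so the step in this assay can only be judged from the spread of the three: compound 2, the one methoxy-bearing compound, is highest, while compound 1, bearing a fluorine on the ring, is lowest. A modest downward step is expected, a number 10 percentage points lower from compound 2 to compound 4 (within the scatter), though a shift of either direction within the scatter would not surprise. Compound 4 is accordingly expected to give about 36%, with a likely range from 15% to 58%.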

Compound 4, a percentage reported as inhibition, at one concentration (the size of the read-out at that concentration, not a potency): 27.1%
The estimate for compound 4 lay 8.9 percentage points above the measured number; the measured number falls inside the stated range.
By their numbers in this assay, from the lowest: compound 1; then compounds 4 and 3 (each within the scatter of the next); then compound 2.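

In this assay, within the data shown here, the first change that can be isolated in one place is methoxy in place of hydrogen on an aromatic carbon, ortho to a methoxy group and para to a group of 9 heavy atoms, and it gives a number 18.9 percentage points lower from compound 2 to compound 4 (beyond the scatter) for this pair. This shows that the aromatic carbon is not indifferent to substitution, since adding this group here goes with less inhibition at the one concentration tested, although the step is modest and compound 4 still gives 27.1% in this assay at that concentration. Nothing shown here bears on why the number falls.

From the compounds shown here alone, it remains open whether a chlorine atom, an amine or a carboxylic acid on this same aromatic carbon would give a step of similar direction and size, and whether the new methoxy would have the same effect without the methoxy group already present. Among these compounds, it is also open how this step at a single concentration would translate into a difference in potency, as the read-out gives no potency for either compound.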